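The source may hold more compounds than are shown below. What is called first, only, known or untested is meant among the compounds shown, and "the series" means these compounds.

Measured compounds in an ADME assay on RAW264.7 cells (Mus musculus) for cytotoxicity, read by MTT assay, with a stated time of 48 h; on this read-out lower numbers stand for stronger inhibition and higher numbers for weaker inhibition:
- compound 1, `COc1cc(NC(=O)c2ccc(C#N)cc2)ccc1NS(C)(=O)=O`: the value for compound 1 is a limit of the assay, > 250000 nM
- compound 2, `CCS(=O)(=O)Nc1ccc(NC(=O)c2ccc(C#N)cc2)cc1OC`: compound 2 gives 66400 nM
- compound 3, `COc1cc(NC(=O)c2ccc(Cl)cc2)ccc1NS(=O)(=O)C(F)(F)F`: compound 3 gives 108000 nM

Compound 3 stands highest of the two numbers shown in this assay; its nearest neighbour is compound 2, and the gap between them lies within the scatter, so the two cannot be told apart. The third value, that of compound 1, is a limit of > 250000 nM in this assay, at which 1 of the 3 values shown sits, and gives no number to rank.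

Compound 4, `COc1cc(NC(=O)c2ccc(C#N)cc2)ccc1NS(=O)(=O)C(F)(F)F`, has not yet been measured. It differs from compound 3 in one place: cyano in place of chloro on an aromatic carbon, so that a 4-chlorophenyl becomes a 4-cyanophenyl at the far end of the amide. Going by the values given here, the only measured step, an at least 3.7-fold lower number from compound 1 to compound 2 (0.57 log units; beyond the scatter), concerns the saturated chain bound to the sulfonyl sulfur, a different part of the shared core, and so says nothing direct about swapping chloro for cyano. Compound 1 does carry the cyano group, but it also differs from compound 3 at the sulfonyl chain and sits at the limit, so no single step can be read from that pair.

Among the compounds with values here, with no measured step bearing on this change, no shift beyond the scatter is expected: the step from compound 3 to compound 4 is estimated at a 1.2-fold higher number from compound 3 to compound 4 (0.08 log units; within the scatter). Compound 4 is therefore expected to give about 130000 nM, in a range from 50000 nM to 300000 nM.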

Compound 4, half-maximal inhibitory concentration: > 250000 nM
Compound 4: only a limit was reported; the forecaster's own chance of this, stated with the estimate: 35%; at least 1.9-fold (0.28 log units) between middle value and limit.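

In this assay, going by these compounds alone, the change from 4-chlorophenyl to 4-cyanophenyl is the first measured change at this end of the molecule, and with trifluoromethyl kept on the sulfonyl sulfur it gives an at least 2.3-fold higher number from compound 3 to compound 4 (0.36 log units; beyond the scatter), so this position can affect the read-out as well as the sulfonyl side. With the 4-cyanophenyl kept, trifluoromethyl in place of ethyl gives an at least 3.7-fold higher number from compound 2 to compound 4 (0.57 log units; beyond the scatter), which leaves ethyl, in compound 2, as the only one of the three sulfonyl groups on this 4-cyanophenyl series with a value that is a number rather than a limit. The remaining step, from compound 1 to compound 4, cannot be read, because both compounds sit at the same limit: the limit of > 250000 nM in this assay, at which 2 of the 4 values shown sit.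

Going by these compounds, how far the true value of compound 4 lies past that limit stays unknown, and so does the full size of both readable steps. Also open, on these data alone, is whether the chloro-to-cyano step would hold with ethyl on the sulfonyl sulfur, and what an amine or a carboxylic acid at the same aromatic carbon, or a propyl or longer chain on the sulfur, would do to the number.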